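Ribose-bearing benzylamines at the ceiling of one cell assay

The source may report more compounds than this note shows. Statements on the series, on what has been measured and on what is new or still open speak of the compounds shown alone.

Three compounds of a shared core were tested in a functional assay on MCF cells (Homo sapiens) for antiproliferative activity, with a stated time of 72 h; a higher number here means a weaker inhibitor, a lower number a stronger inhibitor. Compound 1 `OC[C@H]1O[C@@H](n2cnc3c(NCc4cccc(Br)c4)ncnc32)[C@H](O)[C@@H]1O` carries a 3-bromophenyl group; in this assay compound 1 reaches only the limit > 166000 nM. Compound 2 `COc1ccccc1CNc1ncnc2c1ncn2[C@@H]1O[C@H](CO)[C@@H](O)[C@H]1O` carries a 2-methoxyphenyl group in its place, and in this assay compound 2 likewise reaches only the limit > 166000 nM. Compound 3 `OC[C@H]1O[C@@H](n2cnc3c(NCc4cc(F)cc(F)c4)ncnc32)C(O)C1O` differs in its ring substitution, and in this assay compound 3 also stops at the limit > 166000 nM. The one-point step from compound 1 to compound 2, a step that the two limits leave unreadable from compound 1 to compound 2, therefore cannot be read, and compound 2 stands at the same ceiling as every other compound shown, as the limit of > 166000 nM in this assay, at which 3 of the 3 values shown sit, records.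

The unmeasured compound 4 `COc1cccc(CNc2ncnc3c2ncn3[C@@H]2O[C@H](CO)[C@@H](O)[C@H]2O)c1O` differs from compound 2 by 2-hydroxy-3-methoxyphenyl in place of 2-methoxyphenyl on a saturated chain carbon bound to a nitrogen on an aromatic ring. Among the measured compounds shown here, no measured step of this kind exists, and the only related step, from compound 1 to compound 2, was unreadable, so no direction can be drawn from it. Compound 4 is therefore expected to remain at the limit, and its value in this assay is estimated as 200000 nM, spanning 50000 nM to 1000000 nM. The corresponding step from compound 2 to compound 4 is expected to be a step that the limit leaves unreadable from compound 2 to compound 4, most probably again unreadable.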

Compound 4, half-maximal inhibitory concentration: 20200 nM
For compound 4 the middle estimate is 9.9-fold (1.00 log units) above the measured one; the whole stated range lies above it.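

In this assay, the place on a saturated chain carbon bound to a nitrogen on an aromatic ring turns out to respond to change: 2-hydroxy-3-methoxyphenyl in place of 2-methoxyphenyl gives an at least 8.2-fold lower number from compound 2 to compound 4 (0.91 log units; beyond the scatter), whereas the steps among the compounds held at the limit cannot be read. The same group in place of 3-bromophenyl gives an at least 8.2-fold lower number from compound 1 to compound 4 (0.91 log units; beyond the scatter), so the shift appears from both starting groups, and since each step starts from a limit, its printed size is only a lower bound. Compound 4 is the one compound shown that comes off the ceiling, which leaves it as the only exact value in the set: the limit of > 166000 nM in this assay, at which 3 of the 4 values shown sit.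

The compounds shown leave open whether the hydroxy group, the methoxy group or the two together carry the step, since 2-hydroxy-3-methoxyphenyl is the only group shown with a hydroxy on the ring. As far as these compounds go, a phenyl ring bearing a hydroxy group alone, or an amine or a carboxylic acid in the hydroxy group's place, would be needed to separate these, and how far the value can fall at this place also remains open.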